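Swapping the bicyclic ether group on the shared core

A few compounds are considered here, and "the series" means these few. Any claim that something is new, unique, unknown or untested is made for them only; others in the source may bear on it.

A small set of compounds with a shared core differs only in the bicyclic group attached to the oxygen on the aromatic ring. Compound 1 `Cc1cc(Nc2ncnc3cc(O)c(NC(=O)/C=C/[C@H]4CCCN4C)cc23)ccc1Oc1ccc2nccn2c1` gives 4.08 nM in a functional assay on NCI-N87 cells (Homo sapiens) for inhibition, read by CellTiter-Glo, with a stated time of 72 h; a lower number here means a stronger inhibitor, a higher number a weaker inhibitor. It stands second highest of the three numbers. Its nearest neighbour is compound 2 `Cc1cc(Nc2ncnc3cc(O)c(NC(=O)/C=C/[C@H]4CCCN4C)cc23)ccc1Oc1ccn2ncnc2c1`, which gives 2.65 nM, a change of a 1.5-fold lower number from compound 1 to compound 2 (0.19 log units; within the scatter). Furthest away is compound 3 `Cc1cc(Nc2ncnc3cc(O)c(NC(=O)/C=C/[C@H]4CCCN4C)cc23)ccc1Oc1cnn2cnnc2c1`, which gives 28.3 nM, a change of a 6.9-fold higher number from compound 1 to compound 3 (0.84 log units; beyond the scatter).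

Compound 4 `Cc1cc(Nc2ncnc3cc(O)c(NC(=O)/C=C/[C@H]4CCCN4C)cc23)ccc1Oc1ccn2cnnc2c1` has not been measured. The change from compound 1 is a group of 9 heavy atoms (6 carbon, 3 nitrogen; one five-membered aromatic ring with 3 hetero atoms, one six-membered aromatic ring with 1 hetero atom) in place of a group of 9 heavy atoms (7 carbon, 2 nitrogen; one five-membered aromatic ring with 2 hetero atoms, one six-membered aromatic ring with 1 hetero atom), on an oxygen on an aromatic ring. The entering group has the same counts of atoms, hetero atoms and acceptors as the group that enters in compound 2, differing only in how the ring nitrogens are arranged. The step from compound 1 to compound 2 was within the scatter, so a group of this composition is compatible with a low number. The larger step to compound 3 involved a further nitrogen in the six-membered ring, which compound 4 does not carry.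

Compound 4 is therefore expected to land close to compound 1, with a step of a 1.1-fold higher number from compound 1 to compound 4 (0.04 log units; within the scatter), and is estimated at 4.5 nM, within a range from 1.5 nM to 14 nM.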

Compound 4, half-maximal inhibitory concentration: 32.9 nM
Compound 4: middle estimate off by 7.3-fold (0.86 log units), on the low side, outside the stated range (above it).
By their numbers in this assay, from the lowest: compounds 2 and 1 (each within the scatter of the next); then compounds 3 and 4 (each within the scatter of the next).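

The result shows that, at this place on an oxygen on an aromatic ring, the counts of atoms and hetero atoms in the entering group do not settle the number: compound 2 and compound 4 carry groups with the same counts, differing only in how the ring nitrogens are arranged, yet this assay gives a large step (a 12-fold higher number from compound 2 to compound 4 (1.09 log units; beyond the scatter)). A further nitrogen in the six-membered ring is also not needed to reach the weaker level, since the step from the group of compound 1 is already beyond the scatter (an 8.1-fold higher number from compound 1 to compound 4 (0.91 log units; beyond the scatter)), and compound 4 cannot be told apart from compound 3 (a 1.2-fold higher number from compound 3 to compound 4 (0.07 log units; within the scatter)). No measurement offered here bears on why the arrangement of the ring nitrogens matters so much.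

With only four bicyclic groups, the compounds shown do not separate the part played by each single nitrogen position from that of the arrangement as a whole. They also leave open whether a methyl or an amine placed on the group of compound 4 would shift its number at all.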